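Carbonyl substituent swap, compound 3 to compound 4

The source may hold more compounds than are shown below. What is called first, only, known or untested is meant among the compounds shown, and "the series" means these compounds.

Values in a functional assay on U-87MG ATCC cells (Homo sapiens) for antiproliferative activity (a lower number here means a stronger inhibitor, a higher number a weaker inhibitor), so far
Compound 1 `COCCC(=O)N1CCc2c(C)c3c(n2-c2ccc(C(N)=O)c(c2)N[C@@H](C)[C@H](C)C1)CC(C)(C)CC3=O` gives 54 nM
Compound 2 `Cc1c2c(n3c1CCN(C(=O)[C@@H](N)C(C)C)C[C@@H](C)[C@H](C)Nc1cc-3ccc1C(N)=O)CC(C)(C)CC2=O` gives 48 nM
Compound 3 `Cc1c2c(n3c1CCN(C(=O)C1(N)CC1)C[C@@H](C)[C@H](C)Nc1cc-3ccc1C(N)=O)CC(C)(C)CC2=O` gives 85 nM

Compound 3 stands at 85 nM in this assay and lies within the scatter of both other compounds, so the three do not separate on these numbers. The next structure is compound 4 `Cc1c2c(n3c1CCN(C(=O)[C@@H](O)C(C)C)C[C@@H](C)[C@H](C)Nc1cc-3ccc1C(N)=O)CC(C)(C)CC2=O`, and the change is 1-hydroxy-2-methylpropyl in place of 1-aminocyclopropyl on a carbonyl carbon. Within the data shown here, no measured compound carries 1-hydroxy-2-methylpropyl, so the estimate rests on the three steps at this same carbonyl carbon. The closest is a 1.8-fold higher number from compound 2 to compound 3 (0.25 log units; within the scatter), which exchanges the two amino-bearing groups. The exchanges with 2-methoxyethyl are a 1.1-fold lower number from compound 1 to compound 2 (0.05 log units; within the scatter) and a 1.6-fold higher number from compound 1 to compound 3 (0.20 log units; within the scatter), so a group without an amino substituent also stays within the scatter of the others. Among the measured compounds shown here, all three steps are small, and the series so far tolerates each replacement at this place. No step beyond the scatter is therefore expected in this assay for the new group. The expected step is a 1.4-fold lower number from compound 3 to compound 4 (0.14 log units; within the scatter) and it is estimated to remain within the scatter. The estimate for compound 4 is 62 nM (expected range 28 nM to 140 nM).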

Compound 4, half-maximal inhibitory concentration: 76 nM
The estimate for compound 4 lay 1.2-fold (0.09 log units) below the measured number, within the range that was stated.
By their numbers in this assay, from the lowest: compounds 2, 1, 4 and 3 (each within the scatter of the next).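

In this assay, among these compounds, the exchange of amino for hydroxy on the saturated chain carbon bound to a carbonyl carbon and a saturated chain carbon is seen on its own for the first time, and it gives a 1.6-fold higher number from compound 2 to compound 4 (0.20 log units; within the scatter) with no step beyond the scatter. The open-chain 1-hydroxy-2-methylpropyl, which carries no nitrogen, likewise stays within the scatter of both other groups, with a 1.1-fold lower number from compound 3 to compound 4 (0.05 log units; within the scatter) for the exchange with 1-aminocyclopropyl and a 1.4-fold higher number from compound 1 to compound 4 (0.15 log units; within the scatter) for the exchange with 2-methoxyethyl, so all four groups on this carbonyl carbon remain unseparated and an amino group is not required for a value in this range. Nothing at hand gives a cause for these small steps.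

A carboxylic acid, a phenyl ring or a longer alkyl chain on this carbonyl carbon lies outside the compounds shown, so the limit of this tolerance stays open. On these data alone, the other configuration of the hydroxy-bearing carbon in 1-hydroxy-2-methylpropyl also stays open, as does any read-out other than this assay for these four compounds.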